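This account rests on a few compounds, and the source may have more. Where it says the series, first, only, none or still open, it means among the compounds named here.

Measured so far in a functional assay on HEK293 cells for agonist activity at Free fatty acid receptor 1 (Homo sapiens), read by fluorescence and calcium flux, with a stated time of 10 min; a lower number here means a smaller maximal response, a higher number a larger maximal response:

Compound 1 `CC#C[C@@H](CC(=O)O)c1ccc(OC[C@H]2COc3ccc(F)cc3O2)cc1`: 86%
Compound 2 `CC#C[C@@H](CC(=O)O)c1ccc(OC[C@H]2COc3ccc(OC)cc3O2)cc1`: 91%

Compound 2 carries the nominally larger of the two numbers in this assay, with compound 1 nearest, but the step of a number 5 percentage points higher from compound 1 to compound 2 (within the scatter) is within the scatter, so the two compounds are not separated by these data. Compound 3 `CC#C[C@@H](CC(=O)O)c1ccc(OC[C@H]2COc3ccc(OC(F)(F)F)cc3O2)cc1` has not yet been measured. It differs from compound 2 by trifluoromethyl in place of methyl on an oxygen on an aromatic ring. Among the compounds with values here, the only measured step that bears on it is a number 5 percentage points higher from compound 1 to compound 2 (within the scatter), which also exchanges the group on that part of the shared core and produced no change beyond the scatter. On that basis the step from compound 2 to compound 3 is expected to be small, a number 3 percentage points lower from compound 2 to compound 3 (within the scatter), with no direction that can be asserted beyond the scatter. Compound 3 is therefore estimated at 88% in this assay, with a range of 76% to 100%.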

Compound 3, largest response reached (Emax), in percent of the reference or control that the assay uses: 73%
The estimate for compound 3 lay 15 percentage points above the measured number; the measured number lies below the stated range.
By their numbers in this assay, from the lowest: compound 3; then compounds 1 and 2 (each within the scatter of the next).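

In this assay the group on this aromatic carbon is no longer shown as interchangeable: there is a number 18 percentage points lower from compound 2 to compound 3 (beyond the scatter) and a number 13 percentage points lower from compound 1 to compound 3 (beyond the scatter), whereas fluoro and methoxy remained unseparated, with a number 5 percentage points higher from compound 1 to compound 2 (within the scatter). Trifluoromethyl in place of methyl on the oxygen is therefore the first change in this short series to shift the largest response beyond the scatter, and compound 3 sits apart from both compound 1 and compound 2. Nothing available accounts for this shift.

Open, as far as these compounds go, is whether an ethyl group on that oxygen, or an amine or a nitrile directly on the aromatic carbon, would give numbers like those of compound 1 and compound 2 or like that of compound 3. From the compounds shown here alone, these numbers speak only to largest response, so the effect of the change on potency also stays open.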